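The source may report more compounds than this note shows. Statements on the series, on what has been measured and on what is new or still open speak of the compounds shown alone.

Compound 1 `O=C(CCCCC(S)CCS)NO` gives 9.12%
Compound 2 `O=C(CCCCC1CCSS1)Nc1cccc(C(F)(F)F)c1` gives "not active" (no number reported)

Both compounds were tested in a functional assay on Bel-7402 cells (Homo sapiens) for inhibition, read by MTT assay, with a stated time of 24 h, tested at 1 ug/mL (a higher number here means more inhibition of growth at the concentration tested, a lower number less inhibition of growth), but only compound 1 has a number. Compound 2 stands without a single figure, reported as "not active" (no number reported) and so not placed on the scale. Compound 3 `O=C(CCCCC1CCSS1)Nc1ccc([N+](=O)[O-])c(C(F)(F)F)c1` differs from it by one change nitro in place of hydrogen on an aromatic carbon and this is nitro in place of hydrogen on an aromatic carbon, ortho to a trifluoromethyl group. Among the measured compounds shown here, no measured step speaks to this change, so no shift beyond the usual scatter is expected in this assay for this pair. Compound 3 is expected at about 10% with an estimated range from 0% to 30% in repeat measurements.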

Compound 3, percent growth inhibition at one concentration: 7.46%
The estimate for compound 3 lay 2.5 percentage points above the measured number, and the stated range covers the measured number.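

Among the compounds shown here, with compound 2 at "not active" (no number reported) and compound 3 at 7.46%, no step between them can be read. What the nitro group does to growth inhibition stays open, and no supporting data explain either result.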